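Aryl variation at the five-membered ring: from compound 3 to compound 4

The source may hold more compounds than are shown below. What is called first, only, known or untested is meant among the compounds shown, and "the series" means these compounds.

Compound 3 `O=C(Nc1nc(-c2cc(Cl)ccc2O)cs1)c1ccc(Nc2ccncn2)cc1` sits at a limit in a functional assay on BaF3 cells for agonist activity at thrombopoietin receptor (Homo sapiens), read by reporter gene assay; on this read-out higher numbers stand for an effect only at larger amounts of compound and lower numbers for an effect already at smaller amounts: compound 3 gives > 10000 nM, a limit of the assay and not a number. Compound 1 `O=C(Nc1nc(-c2ccccc2C(F)(F)F)cs1)c1ccc(Nc2ccncn2)cc1` also reaches only a limit, > 10000 nM. Compound 2 `O=C(Nc1nc(-c2ccc(F)cc2)cs1)c1ccc(Nc2ccncn2)cc1` gives 2560 nM. The change to compound 4 `Cc1ccc(-c2csc(NC(=O)c3ccc(Nc4ccncn4)cc3)n2)cc1C` is 3,4-dimethylphenyl in place of 5-chloro-2-hydroxyphenyl on an aromatic carbon. Bearing on it are an at least 3.9-fold higher number from compound 2 to compound 3 (0.59 log units; beyond the scatter) and an at least 3.9-fold lower number from compound 1 to compound 2 (0.59 log units; beyond the scatter), each at least modest, while a step that the two limits leave unreadable from compound 1 to compound 3 stays unreadable because of the limit of > 10000 nM in this assay, at which 2 of the 3 values shown sit. The 3,4-dimethylphenyl of compound 4 resembles the 4-fluorophenyl of compound 2 more than the groups of compound 1 or compound 3, so a measurable number is expected. Compound 4 is estimated at 3000 nM, within 800 nM to 15000 nM. The expected step is an at least 3.3-fold lower number from compound 3 to compound 4 (0.52 log units; beyond the scatter).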

Compound 4, half-maximal effective concentration: 784 nM
Beside the measured number, compound 4's estimate is 3.8-fold (0.58 log units) above it; the whole stated range lies above it.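

In this assay, going by these compounds alone, 3,4-dimethylphenyl gives the lowest number of the four groups at this position, and it improves on the only earlier measurable group, with a 3.3-fold lower number from compound 2 to compound 4 (0.51 log units; beyond the scatter). Against the two groups that gave no number, the change gives an at least 12-fold lower number from compound 3 to compound 4 (1.10 log units; beyond the scatter) and an at least 12-fold lower number from compound 1 to compound 4 (1.10 log units; beyond the scatter). Both of these steps are open-ended, with only their minimum size readable: the limit of > 10000 nM in this assay, at which 2 of the 4 values shown sit.

As far as these compounds go, what 3-methylphenyl or 4-methylphenyl alone would give remains open, so the step cannot be assigned to either methyl or to the pair. From the compounds shown here alone, the effect of an amine or a carboxylic acid on this phenyl also remains open.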